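This account rests on a few compounds, and the source may have more. Where it says the series, first, only, none or still open, it means among the compounds named here.

Values in an ADME assay on cells (spleen, Mus musculus, strain C57BL/6) for inhibition, read by flow cytometry and propidium iodide staining, with a stated time of 24 h, at 37 degrees C; on this read-out higher numbers stand for an effect only at larger amounts of compound and lower numbers for an effect already at smaller amounts
- compound 1 `O=C(Cn1cc(CO)nn1)NCc1ccccc1` gives 490 uM
- compound 2 `NCc1cn(CC(=O)NCc2ccccc2)nn1` gives > 2000 uM
- compound 3 `Cc1ccccc1-c1cn(CC(=O)NCc2ccccc2)nn1` gives 940 uM

The value of compound 2 is a limit of the assay and not a number. Compound 3 stands level with compound 1, since the gap between the two true numbers lies within the scatter (a 1.9-fold higher number from compound 1 to compound 3 (0.28 log units; within the scatter)). Compound 4 `COc1ccc(-c2cn(CC(=O)NCc3ccccc3)nn2)cc1` has 4-methoxyphenyl in place of 2-methylphenyl on an aromatic carbon. Two measured steps changed this same carbon, the one just given and a modest one (an at least 2.1-fold lower number from compound 2 to compound 3 (0.32 log units; beyond the scatter)). Neither exchanges one substituted phenyl for another, so they give little reason to expect a real shift in this assay. The expected step is small and within the scatter (a 1.1-fold lower number from compound 3 to compound 4 (0.04 log units; within the scatter)). For compound 4 the estimate is 850 uM, with an expected range from 330 uM to 2000 uM.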

Compound 4, concentration for half-maximal effect: "non-toxic" (no number reported)
Compound 4: no number reported, and the estimate cannot be compared.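

Among these compounds, compound 4 is reported only as "non-toxic", without a number, so no step from compound 3 to compound 4 can be read. Left open is whether this label corresponds to the limit given for compound 2: the limit of > 2000 uM in this assay, at which 1 of the 4 values shown sits.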